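Chain length on a piperazinyl-pyridine core in a seizure model

The source may report more compounds than this note shows. Statements on the series, on what has been measured and on what is new or still open speak of the compounds shown alone.

Measured:
compound 1, `CCCCCCc1cccc(N2CCNCC2)n1`: 10 mg/kg
compound 2, `CCCCCCCCCCc1cccc(N2CCNCC2)n1`: 30 mg/kg
compound 3, `CCCCc1cccc(N2CCNCC2)n1`: 30 mg/kg

In a functional assay on the whole organism with Mus musculus as the target, in the maximal electroshock model, with a stated time of 120 min (on this read-out higher numbers stand for an effect only at larger amounts of compound and lower numbers for an effect already at smaller amounts), compound 1 gives 10 mg/kg, the lowest of the three numbers. The change butyl in place of hydrogen on a saturated chain carbon, six bonds along the chain from an aromatic carbon gives a 3.0-fold higher number from compound 1 to compound 2 (0.48 log units; beyond the scatter). The core of compound 3 differs from that of compound 1 by hydrogen in place of ethyl on a saturated chain carbon, four bonds along the chain from an aromatic carbon; compound 3 gives 30 mg/kg, and compound 2 gives 30 mg/kg, the two being within the scatter of each other.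

Compound 4, `CCCCCCCCc1cccc(N2CCNCC2)n1`, is not yet measured. It differs from compound 3 by butyl in place of hydrogen on a saturated chain carbon, four bonds along the chain from an aromatic carbon. This is the same kind of change as that from compound 1 to compound 2, but not the same: there the entering butyl sits six bonds along the chain from an aromatic carbon, here four bonds along the chain. Compound 4 therefore carries a chain between those of compound 1 and compound 2. With compound 1 at 10 mg/kg and compound 2 at 30 mg/kg, a number between them is expected, so the step from compound 3 to compound 4 is estimated as a 1.5-fold lower number from compound 3 to compound 4 (0.18 log units; within the scatter), a smaller move than the earlier one. The estimate for compound 4 in this assay is 20 mg/kg, expected between 8 mg/kg and 50 mg/kg.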

Compound 4, minimum effective dose: 10 mg/kg
Beside the measured number, compound 4's estimate is 2.0-fold (0.30 log units) above it, within the range that was stated.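

In this assay, butyl in place of hydrogen gives a 3.0-fold lower number from compound 3 to compound 4 (0.48 log units; beyond the scatter), so this change does not carry from one core to the other: the same change on two cores in this assay, a 3.0-fold higher number (0.48 log units; beyond the scatter) from compound 1 to compound 2 and a 3.0-fold lower number (0.48 log units; beyond the scatter) from compound 3 to compound 4, 9.0-fold (0.95 log units) apart, beyond the scatter of two such steps. Hydrogen in place of ethyl fails to carry over in the same way, here giving a 3.0-fold lower number from compound 2 to compound 4 (0.48 log units; beyond the scatter): the same change on two cores in this assay, a 3.0-fold higher number (0.48 log units; beyond the scatter) from compound 1 to compound 3 and a 3.0-fold lower number (0.48 log units; beyond the scatter) from compound 2 to compound 4, 9.0-fold (0.95 log units) apart, beyond the scatter of two such steps. Ethyl in place of hydrogen gives no change at the digits printed from compound 1 to compound 4 (within the scatter), so the hexyl and octyl chains cannot be told apart on this read-out, and the four compounds show that the result of a chain change depends on the chain it starts from, but not why.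

Open, as far as these compounds go, is how a heptyl or a nonyl chain would read on the shared core, and whether a chain longer than decyl or shorter than butyl would follow the same course. Also open, from the compounds shown here alone, is how a branched chain, or a chain carrying an ether oxygen or a terminal phenyl, would read.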